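The compounds below may be only part of what the source reports. "The series", "measured", "known", "first", "only" and "open" are said of these compounds alone.

Compound 1 `Cc1cn([C@@H]2C[C@H](O)[C@@H](CNC(=O)Nc3ccc(Cl)cc3)O2)c(=O)[nH]c1=O` is the starting point here. In an ADME assay on MRC5 cells (Homo sapiens) for cytotoxicity (on this read-out higher numbers stand for lower toxicity in this test and lower numbers for higher toxicity in this test), compound 1 gives > 50000 nM, which is a limit of the assay and not a number. Compound 2 `Cc1cn([C@@H]2C[C@H](O)[C@@H](CNC(=O)Nc3cccc(COc4ccccc4)c3)O2)c(=O)[nH]c1=O` gives > 50000 nM, again a limit. Compound 3 `Cc1cn([C@@H]2C[C@H](O)[C@@H](CNC(=S)Nc3ccc(OCc4ccccc4)cc3)O2)c(=O)[nH]c1=O` gives > 50000 nM, also a limit. Taken together, the picture is the limit of > 50000 nM in this assay, at which 3 of the 3 values shown sit, so compound 1 stands at the limit, with no exact number to compare.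

Compound 4 `Cc1ccc2nc(-c3ccc(NC(=O)NC[C@H]4O[C@H](n5cc(C)c(=O)[nH]c5=O)C[C@@H]4O)cc3)sc2c1` keeps the core of compound 1 and carries 6-methyl-1,3-benzothiazol-2-yl in place of chloro on an aromatic carbon, para to a large group: 6-methyl-1,3-benzothiazol-2-yl in place of chloro on an aromatic carbon.

Among the measured compounds shown here, no measured step between two compounds is available to guide this change. Only a small move toward lower numbers in this assay is expected, possibly none beyond the scatter, and that expectation rests on (the limit of > 50000 nM in this assay, at which 3 of the 3 values shown sit). The expected change is an at least 1.2-fold lower number from compound 1 to compound 4 (0.09 log units; that floor lies within the scatter), and the result may again be reported only as a limit.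

For compound 4 the estimated value is 40000 nM, with an expected range from 15000 nM to 60000 nM.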

Compound 4, half-maximal cytotoxic concentration: > 50000 nM
Compound 4: a limit, no number (the forecaster's own chance of this, stated with the estimate: 65%); middle value at least 1.2-fold (0.09 log units) from the limit.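

Among the compounds shown here, compound 4, like compound 1, is reported only as a limit in this assay, so no step between the two can be read. The compounds shown leave open what exact number any of them would give, and which change would produce one: the limit of > 50000 nM in this assay, at which 4 of the 4 values shown sit.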